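The source may report more compounds than this note shows. Statements on the series, on what has been measured and on what is new or still open speak of the compounds shown alone.

Working notes on the series.

Two amide analogues of the shared core have been run so far in a functional assay on A549 cells (Homo sapiens) for inhibition, read by MTT assay, with a stated time of 48 h; a higher number here means a weaker inhibitor, a lower number a stronger inhibitor. Compound 1 `COc1ccc2c(=O)c(/C=C/C(=O)Nc3ccc(Cl)cc3)coc2c1` carries a 4-chlorophenyl on the amide nitrogen. In this assay compound 1 gives only a limit, > 100000 nM, and no number. Compound 2 `Cc1ccccc1NC(=O)/C=C/c1coc2cc(O)ccc2c1=O` carries a 2-methylphenyl in the same position. In this assay compound 2 likewise sits at a limit, > 100000 nM, so no inhibitory concentration is available for it. Where compound 2 stands is therefore fixed only by the limit of > 100000 nM in this assay, at which 2 of the 2 values shown sit; nothing in the data places it above or below the other analogue.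

The next analogue, compound 3 `Cc1ccc(CNC(=O)/C=C/c2coc3cc(O)ccc3c2=O)cc1`, differs from compound 2 in one place: 4-methylbenzyl in place of 2-methylphenyl on an amide-type nitrogen. Going by the values given here, since both values so far are limits, no measured step exists from which to read the size of this change, and nothing indicates that it should move the read-out beyond the scatter.

Compound 3 is therefore expected to stay near the limit, estimated at 120000 nM with a range of 30000 nM to 500000 nM. The step that this estimate implies, a step that the limit leaves unreadable from compound 2 to compound 3, is expected to be none beyond the scatter.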

Compound 3, half-maximal inhibitory concentration: 17400 nM
Estimate against measurement, compound 3: 6.9-fold (0.84 log units) above; the whole stated range lies above it.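

In this assay, going by these compounds alone, 4-methylbenzyl in place of 2-methylphenyl on an amide-type nitrogen gives an at least 5.7-fold lower number from compound 2 to compound 3 (0.75 log units; beyond the scatter), so the read-out does respond to what sits at this position, which the earlier compounds, both held at a limit, could not show. Within the data shown here, compound 3 is the only one of the three compounds with a number rather than a limit, and it gives the series a measured reference point for further changes on this nitrogen. The true size of the step stays unknown, and it can be stated only as a lower bound because compound 2 has a limit and no number: the limit of > 100000 nM in this assay, at which 2 of the 3 values shown sit.

The change replaces one group with another that differs both in the carbon count and in how the ring is attached and substituted, so the compounds shown do not tell which of these features accounts for the step. A 2-methylbenzyl or a 4-methylphenyl on the same nitrogen would separate them, while a 2-phenylethyl would test whether a longer chain carries the trend further.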